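Working notes: from compound 2 to compound 4

This account rests on a few compounds, and the source may have more. Where it says the series, first, only, none or still open, it means among the compounds named here.

Compound 1 `CNC(=N)Nc1nc(-c2ccc(OC)cc2)c(-c2ccc(OC)cc2)s1` gives 1.2 uM in a functional assay (aorta) with Rattus norvegicus as the target; on this read-out lower numbers stand for an effect already at smaller amounts and higher numbers for an effect only at larger amounts of compound.
Compound 2 `COc1ccc(-c2nc(/N=C(\N)NC(C)C)sc2-c2ccc(OC)cc2)cc1` gives 9.1 uM in this assay.
Compound 3 `COc1ccc(-c2nc(/N=C(\N)NC3CCCCC3)sc2-c2ccc(OC)cc2)cc1` gives > 100 uM in this assay, which is a limit of the assay and not a number.

Compound 2 holds the highest of the two numbers; its nearest neighbour is compound 1, with a 7.6-fold higher number from compound 1 to compound 2 (0.88 log units; beyond the scatter). Compound 3 sits at the limit (the limit of > 100 uM in this assay, at which 1 of the 3 values shown sits), and from compound 2 the step is an at least 10-fold higher number from compound 2 to compound 3 (1.04 log units; beyond the scatter). Compound 4 `COc1ccc(-c2nc(CNC(=O)CSC)sc2-c2ccc(OC)cc2)cc1` differs from compound 2 by a group of 7 heavy atoms (4 carbon, 1 nitrogen, 1 oxygen, 1 sulfur; no ring) in place of a group of 7 heavy atoms (4 carbon, 3 nitrogen; no ring), on an aromatic carbon. Both measured steps at this same aromatic carbon raised the number, one modest and one large, but neither introduced a group resembling the one entering here, so the direction is open. Compound 4 is expected near 30 uM, between 5 uM and 100 uM, the estimated step being a 3.3-fold higher number from compound 2 to compound 4 (0.52 log units; beyond the scatter).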

Compound 4, concentration for half-maximal effect: 6 uM
The estimate for compound 4 lay 5.0-fold (0.70 log units) above the measured number; low and high end bracket the measured number.
By their numbers in this assay, from the lowest: compound 1; then compounds 4 and 2 (each within the scatter of the next). At a limit, above all of these: compound 3.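

At this aromatic carbon, ((((methylsulfanyl)methyl)carbonyl)amino)methyl can take the place of the three-nitrogen group of compound 2 with no change beyond the scatter in this assay: a 1.5-fold lower number from compound 2 to compound 4 (0.18 log units; within the scatter). The three-nitrogen arrangement is therefore not required for a number in this range, although compound 1 remains apart: a 5.0-fold higher number from compound 1 to compound 4 (0.70 log units; beyond the scatter). The step from the cyclohexyl compound is only bounded, an at least 16-fold lower number from compound 3 to compound 4 (1.22 log units; beyond the scatter), and compound 3 is a limit and not a number: the limit of > 100 uM in this assay, at which 1 of the 4 values shown sits.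

Which part of the entering group matters remains open. A carboxylic acid, a primary amine or a longer chain ending in methoxy at this carbon would help separate the contribution of the amide from that of the sulfur.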